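Methyl on the Saturated Ring and Cytotoxicity

The compounds below may be only part of what the source reports. "The series", "measured", "known", "first", "only" and "open" are said of these compounds alone.

The compounds here were tested in an ADME assay on MRC5 cells (Homo sapiens) for cytotoxicity, read by fluorescence, with a stated time of 72 h; on this read-out higher numbers stand for weaker inhibition and lower numbers for stronger inhibition. Compound 1 `CC1(COc2ccc(-c3ccc(F)cc3)cc2)Cn2cc([N+](=O)[O-])nc2O1` and compound 2 `O=[N+]([O-])c1cn2c(n1)OC(COc1ccc(-c3ccc(F)cc3)cc1)C2` share a core and differ by methyl in place of hydrogen on a saturated ring carbon. In this assay compound 2 reaches only a limit, > 64000 nM. Compound 1 likewise reaches only a limit in this assay, > 64000 nM. The step that the two limits leave unreadable from compound 2 to compound 1 therefore cannot be sized. Compound 3 `O=[N+]([O-])c1cn2c(n1)OC(COc1ccc(-c3ccc(C(F)(F)F)cc3)nc1)C2` has a different core; the difference between the two cores is not broken down here. In this assay compound 3 also gives only a limit, > 64000 nM. All three values sit at the limit of > 64000 nM in this assay, at which 3 of the 3 values shown sit.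

Compound 4 `CC1(COc2ccc(-c3ccc(C(F)(F)F)cc3)nc2)Cn2cc([N+](=O)[O-])nc2O1` has not been measured. It differs from compound 3 by methyl in place of hydrogen on a saturated ring carbon, the same change as that from compound 2 to compound 1, at the same place. Since the step from compound 2 to compound 1 was a step that the two limits leave unreadable from compound 2 to compound 1 and every value shown sits at the limit of > 64000 nM in this assay, at which 3 of the 3 values shown sit, the step of a number no higher from compound 3 to compound 4 (the limit leaves the size open) is expected to be small or unreadable. On that basis compound 4 is expected to give about 64000 nM in this assay, most likely again as a limit.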

Compound 4, half-maximal inhibitory concentration: > 64000 nM
Compound 4: a limit, no number; the forecaster's own chance of this, stated with the estimate: 85%; the middle value lies on the limit itself.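

Compound 3 and compound 4 each give only a limit in this assay, not a number, so no size can be read for the step of methyl in place of hydrogen on a saturated ring carbon: the limit of > 64000 nM in this assay, at which 4 of the 4 values shown sit. The compounds shown leave open whether this methyl changes cytotoxicity at all, and what concentration, if any, would produce half-maximal inhibition.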